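The source may hold more compounds than are shown below. What is called first, only, known or untested is meant among the compounds shown, and "the series" means these compounds.

In a functional assay on SW480 cells (Homo sapiens) for antiproliferative activity, read by MTT assay, with a stated time of 48 h (a lower number here means a stronger inhibitor, a higher number a weaker inhibitor), compound 1 (`CC(CCO)n1cnc2c(Cl)ncnc21`) gives > 50000 nM, which is a limit and not a number. Compound 2 (`CCCCC(CCO)n1cnc2c(Cl)ncnc21`) gives > 50000 nM, also a limit, and so stands at the limit of > 50000 nM in this assay, at which 2 of the 3 values shown sit. Compound 3 (`CCCCC(CCO)n1cnc2c(Cl)nc(Cl)nc21`) gives 30900 nM, a measured number.

Compound 4 (`CCCCCCCCCC(CCO)n1cnc2c(Cl)ncnc21`) differs from compound 2 by pentyl in place of hydrogen on a saturated chain carbon, five bonds along the chain from an aromatic nitrogen. The nearest measured change on the chain is a step that the two limits leave unreadable from compound 1 to compound 2, so it provides no size to carry over. The other measured change, at a different place, is an at least 1.6-fold lower number from compound 2 to compound 3 (0.20 log units; that floor lies within the scatter). Only a modest lowering in this assay is therefore expected, and possibly none beyond the scatter. The expected change is an at least 1.3-fold lower number from compound 2 to compound 4 (0.11 log units; that floor lies within the scatter), and another limit remains quite possible. Compound 4 is estimated at 38000 nM, with an expected range of 14000 nM to 90000 nM.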

Compound 4, half-maximal inhibitory concentration: 1150 nM
Beside the measured number, compound 4's estimate is 33-fold (1.52 log units) above it; measured number below the stated range.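

In this assay, among these compounds, the pentyl change on this saturated chain carbon gives an at least 43-fold lower number from compound 2 to compound 4 (1.63 log units; beyond the scatter) and is the first step on the chain with a readable size, since the earlier propyl step lay between two limits and could not be read. Among the compounds shown here, it is also the first step printed as beyond the scatter. The size is a floor and not a measured gap, because compound 2 stands at a limit: the limit of > 50000 nM in this assay, at which 2 of the 4 values shown sit.

As far as these compounds go, whether a longer chain, or a chain ending in an amine, holds this gain stays open. Also open, from the compounds shown here alone, is whether the chloro change on the aromatic carbon adds to the pentyl change.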